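A few compounds are considered here, and "the series" means these few. Any claim that something is new, unique, unknown or untested is made for them only; others in the source may bear on it.

Measured compounds:
- compound 1, `O=c1[nH]c2ccccc2cc1/C=N/O`: 31800 nM
- compound 2, `NS(=O)(=O)CC(=O)N/N=C/c1cc2ccccc2[nH]c1=O`: 8910 nM
- compound 3, `O=c1[nH]c2ccccc2cc1/C=N/Nc1ccc([N+](=O)[O-])cc1`: 11400 nM

Three compounds sharing the core of compound 1 have been run in a functional assay, read by spectrophotometry, with a stated time of 3 min; on this read-out lower numbers stand for stronger inhibition and higher numbers for weaker inhibition. Compound 1 gives 31800 nM, the highest of the three numbers. Compound 3 stands nearest to it with 11400 nM, a gap beyond the scatter, and compound 2 lies furthest away with 8910 nM, also beyond the scatter. Compound 1 is thus the weakest of the three in this assay.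

Compound 4, `CCCC/N=C/c1cc2ccccc2[nH]c1=O`, has not been measured yet. It differs from compound 1 in one place: butyl in place of hydroxy on a double-bonded nitrogen. For the measured compounds named here, no step between two measured compounds matches this change, so there is no direct precedent for its size. The two measured analogues with a larger substituent on the double-bonded nitrogen show lower numbers than compound 1, but neither is a single-change comparison, and nothing in the data singles out the butyl group.

The step from compound 1 to compound 4 is therefore expected to be small, at most toward lower numbers and likely within the scatter, a 1.6-fold lower number from compound 1 to compound 4 (0.20 log units; within the scatter). Compound 4 is estimated at 20000 nM in this assay, with a range from 6000 nM to 70000 nM.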

Compound 4, half-maximal inhibitory concentration: 1810000 nM
Compound 4: the middle estimate sits 91-fold (1.96 log units) below what was measured, outside the stated range (above it).
By their numbers in this assay, from the lowest: compounds 2 and 3 (each within the scatter of the next); then compound 1; then compound 4.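

In this assay, for the compounds shown here, the exchange of hydroxy for butyl on a double-bonded nitrogen brings a 57-fold higher number from compound 1 to compound 4 (1.76 log units; beyond the scatter) and is the first change at this place that can be read on its own. Going by these compounds alone, it shows that this position does not accept every group: the numbers of the earlier compounds gave no sign of a step of this size, and here the large step is tied to a single change, in which a hydroxy with its hydrogen-bond donor and acceptor gives way to a butyl with neither. No measurement among those shown accounts for the size of this step, so the change in group size and the absence of donor and acceptor cannot be told apart.

From the compounds shown here alone, what stays open is whether the chain itself or the missing hydroxy drives the rise, and a shorter chain such as methyl or ethyl on the same nitrogen would bear on the first, while a butyl ending in a hydroxy or an amine would bear on the second. Going by these compounds, a methoxy in place of the hydroxy would likewise be a single change at this place, and its effect on the number remains unknown.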